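The source may report more compounds than this note shows. Statements on the series, on what has been measured and on what is new or still open speak of the compounds shown alone.

Series notes. In a physicochemical assay for lipophilicity, at pH 7.4 (a higher number here means a more lipophilic compound, a lower number a more polar compound), compound 1 `O=C(Nc1cccc(Cl)c1)c1cc(C(F)(F)F)ccc1OCc1ccc(F)cc1` gives 8.7, compound 3 `O=C(Nc1cccnc1)c1cc(C(F)(F)F)ccc1OCc1ccccc1` gives 6.3, and compound 2 `O=C(Nc1ccnnc1)c1cc(N2CCC(F)CC2)ccc1OCc1ccccc1` gives 5.1. Compound 2 stands lowest of the three: compound 3 sits above it beyond the scatter, compound 1 further above, also beyond the scatter. Compound 4 `O=C(Nc1ccnnc1)c1cc(N2C[C@H]3COC[C@H]3C2)ccc1OCc1ccccc1` is not yet measured. Compound 4 differs from compound 2 in one place: a group of 8 heavy atoms (6 carbon, 1 nitrogen, 1 oxygen; 2 five-membered non-aromatic rings with 1 hetero atom each) in place of a group of 7 heavy atoms (5 carbon, 1 nitrogen, 1 fluorine; one six-membered non-aromatic ring with 1 hetero atom), on an aromatic carbon. Among the measured compounds shown here, no measured step of this kind exists. The change is expected to move this assay down, by a step estimated at a number 0.80 log units lower from compound 2 to compound 4 (beyond the scatter), beyond the scatter. Compound 4 is accordingly expected to give 4.3 in this assay, with a range from 3.6 to 5.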

Compound 4, distribution coefficient: 4.5
For compound 4 the middle estimate is 0.20 log units below the measured one; the range from low to high includes it.
By their numbers in this assay, from the lowest: compound 4; then compound 2; then compound 3; then compound 1.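

Among the compounds shown here, at the aromatic carbon para to a benzyloxy group, this assay gives a number 0.60 log units lower from compound 2 to compound 4 (beyond the scatter) when a group with two five-membered non-aromatic rings replaces 4-fluoropiperidin-1-yl, the first one-place step. The number at this position therefore moves with the ring group, and it falls even though the entering group is the larger by heavy atoms. A carboxylic acid, a primary amine or a longer alkyl chain on this carbon remains an open case, as does whether the step carries over to the core of compound 1 or compound 3. Nothing in hand bears on the cause of the step.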